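The source may report more compounds than this note shows. Statements on the series, on what has been measured and on what is new or still open speak of the compounds shown alone.

Compound 1 `COc1ccccc1/C=C(\C(=O)c1ccc(Br)cc1)S(=O)(=O)c1ccc(C)cc1` and compound 2 `COc1ccccc1/C=C(\C(=O)c1ccc(Cl)cc1)S(=O)(=O)c1ccc(C)cc1` are built on one core and differ at a single point. In a functional assay on DU-145 cells (Homo sapiens) for inhibition, read by trypan blue exclusion, with a stated time of 96 h (a higher number here means a weaker inhibitor of growth, a lower number a stronger inhibitor of growth), compound 1 gives 1000 nM, and compound 2 gives 1000 nM. The change between them, (chloro in place of bromo on an aromatic carbon), produced no change at the digits printed from compound 1 to compound 2 (within the scatter). Compound 3 `Cc1ccc(S/C(=C/c2c[nH]c3ccc(Cl)cc23)C(=O)c2ccc(Br)cc2)cc1` rests on another core; how its core differs from that of compound 1 is not broken down here. In this assay compound 3 gives 1000 nM, level with compounds 1 and 2 within the scatter. Compound 4 `Cc1ccc(S/C(=C/c2c[nH]c3ccc(Cl)cc23)C(=O)c2ccc(Cl)cc2)cc1` carries the same change on the core of compound 3: chloro in place of bromo on an aromatic carbon. The expected step is no change at the digits printed from compound 3 to compound 4 (within the scatter), because that same change gave no change at the digits printed from compound 1 to compound 2 (within the scatter). For compound 4 the value in this assay is estimated at 1000 nM, between 500 nM and 2000 nM.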

Compound 4, concentration for 50% growth inhibition: 1000 nM
For compound 4 middle estimate and measured number coincide at the digits printed, and the stated range covers the measured number.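

In this assay, going from 4-bromophenyl to 4-chlorophenyl gave no change at the digits printed from compound 3 to compound 4 (within the scatter), and this agrees with the earlier step on the other core: the same change on two cores in this assay, no change at the digits printed (within the scatter) from compound 1 to compound 2 and no change at the digits printed (within the scatter) from compound 3 to compound 4, 1.0-fold (0.00 log units) apart, within the scatter of two such steps

Across these two cores, then, the change carried over without any visible effect on growth inhibition in this assay. This does not show that it would behave the same way on a further core or in another assay, and it gives no reason why the two halogens read alike.

The compounds shown leave open whether a different group at this place, such as a nitrile, an amine or a carboxylic acid, would shift the value. Also open, from the compounds shown here alone, is how a plain phenyl would compare with the two halogenated rings.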